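A few compounds are considered here, and "the series" means these few. Any claim that something is new, unique, unknown or untested is made for them only; others in the source may bear on it.

Compound 1 `CN1CCC[C@H](Cn2c(CN(C)[C@@H]3CCCc4cccnc43)nc3ccccc32)C1` belongs to a small set of three close analogues sharing one core. In an ADME assay on HOS cells (Homo sapiens) for cytotoxicity (a higher number here means that more compound is tolerated, a lower number that less compound is tolerated), compound 1 gives 3600 nM, the lowest of the three numbers, so it is the least tolerated of the set. Compound 3 `CN(Cc1nc2ccccc2n1CC1CCNC1)C1CCCc2cccnc21` gives 7700 nM in this assay, and compound 2 `CN1CC(Cn2c(CN(C)C3CCCc4cccnc43)nc3ccccc32)C1` gives 14000 nM. Among the measured compounds shown here, the only single-point step among the measured compounds, a 1.8-fold lower number from compound 2 to compound 3 (0.26 log units; within the scatter), concerns the substituent on the saturated chain carbon bound to the aromatic nitrogen and tells nothing about configuration.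

Compound 4 `CN1CCC[C@@H](Cn2c(CN(C)[C@H]3CCCc4cccnc43)nc3ccccc32)C1` is the mirror image of compound 1: the two compounds have the same atoms and bonds and differ only in configuration as drawn: 2 of 2 stereo elements differ (all stereocentres are inverted: mirror images); a stereocentre at a saturated ring carbon is drawn S in compound 1 and R in compound 4; a stereocentre at a saturated ring carbon is drawn R in compound 1 and S in compound 4. For the measured compounds named here, no measured pair in this set differs only in configuration, so nothing here shows how the inversion of both stereocentres affects the cytotoxic concentration. In the absence of such a step, the expected change in this assay for compound 4 is none beyond the scatter, but with wider uncertainty than a repeat measurement would carry. The step from compound 1 to compound 4 is therefore estimated as no change at the digits printed from compound 1 to compound 4 (within the scatter). For compound 4 the expected value in this assay is 3600 nM, in the range 1400 nM to 9500 nM.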

Compound 4, half-maximal cytotoxic concentration: 3500 nM
Estimate against measurement, compound 4: 1.0-fold (0.01 log units) above; measured number inside the range.
By their numbers in this assay, from the lowest: compounds 4 and 1 (each within the scatter of the next); then compounds 3 and 2 (each within the scatter of the next).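

In this assay, among the compounds shown here, the set now holds a step that concerns configuration alone, a 1.0-fold lower number from compound 1 to compound 4 (0.01 log units; within the scatter), whereas the only earlier step concerned the substituent on the saturated chain carbon bound to an aromatic nitrogen. This comparison separates the effect of configuration from any change in constitution: the fact that compounds 1 and 4 differ only in the configuration as drawn. Inverting both stereocentres together leaves the cytotoxic concentration within the scatter for this pair, so in these two compounds, the mirror-image relationship between the two drawn configurations has no readable effect on how much compound is tolerated.

The compounds shown leave open what happens when only one of the two stereocentres is inverted, as the step here changes both at once and so cannot assign any contribution to either stereocentre, and opposing contributions from the two are not ruled out. Also open, from the compounds shown here alone, is whether configuration would remain without effect in this assay if a carboxylic acid or a primary amine stood in place of the substituent on the saturated chain carbon bound to an aromatic nitrogen.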